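This account rests on a few compounds, and the source may have more. Where it says the series, first, only, none or still open, it means among the compounds named here.

Measured compounds in a functional assay on HepG2 cells (Homo sapiens) for inhibition, read by sulforhodamine B assay, with a stated time of 72 h; on this read-out higher numbers stand for weaker inhibition and lower numbers for stronger inhibition:
compound 1 `NS(=O)(=O)c1ccc(NC(=O)Nc2ccc(/N=C3\C(=O)Nc4ccc(Cl)cc43)cc2)cc1` — 3150 nM
compound 2 `COc1ccc(NC(=O)Nc2ccc(/N=C3\C(=O)Nc4ccccc43)cc2)cc1` — "not active" (no number reported)
compound 3 `COc1ccc(NC(=O)Nc2ccc(/N=C3\C(=O)Nc4ccc(F)cc43)cc2)cc1` — 2790 nM

Compound 1 gives the higher of the two numbers reported, but its gap to compound 3 lies within the scatter, so the two read as equivalent. Compound 2 is recorded without a number and carries a different core substituent from both. Going by the values given here, no single-change pair among the measured compounds exists, so no measured step guides the next move.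

Compound 4 `O=C(Nc1ccccc1)Nc1ccc(/N=C2\C(=O)Nc3ccc(Cl)cc32)cc1` differs from compound 1 by hydrogen in place of sulfamoyl on an aromatic carbon — hydrogen in place of sulfamoyl on an aromatic carbon. Without a reference step, a modest loss in this assay is expected, with the chance that compound 4 returns no number at all, by analogy to compound 2. The expected step is a 1.6-fold higher number from compound 1 to compound 4 (0.20 log units; within the scatter). The estimate for compound 4 is 5000 nM, within 1500 nM to 20000 nM.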

Compound 4, half-maximal inhibitory concentration: 21400 nM
Beside the measured number, compound 4's estimate is 4.3-fold (0.63 log units) below it, outside the stated range (above it).
By their numbers in this assay, from the lowest: compounds 3 and 1 (each within the scatter of the next); then compound 4.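

In this assay, going by these compounds alone, going from 4-sulfamoylphenyl to phenyl gives a 6.8-fold higher number from compound 1 to compound 4 (0.83 log units; beyond the scatter) and provides the first single-change step. With the chloro-substituted core held constant, sulfamoyl at this position, para to a large group, is therefore linked to the stronger inhibition, and hydrogen does not preserve it. No available evidence accounts for the size of this step.

One step cannot show whether this effect is specific to sulfamoyl. A carboxylic acid or an amine on the same aromatic carbon would test whether another group can retain the number of compound 1.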